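Lengthening the alkyne chain at the cytotoxicity limit

This account rests on a few compounds, and the source may have more. Where it says the series, first, only, none or still open, it means among the compounds named here.

Measured so far in a functional assay on HEL cells (Homo sapiens) for cytotoxicity (a higher number here means that more compound is tolerated, a lower number that less compound is tolerated), for two compounds:
Compound 1 `CCCCCCc1cc2cn([C@H]3C[C@H](O)[C@@H](CO)O3)c(=O)nc2o1` gives > 200000 nM as a limit
Compound 2 `C#CCCCc1cc2cn([C@H]3C[C@H](O)[C@@H](CO)O3)c(=O)nc2o1` gives > 200000 nM as a limit

Compound 2 stands at > 200000 nM in this assay and this is a limit, not a number. The only thing on record for the two compounds is the limit of > 200000 nM in this assay, at which 2 of the 2 values shown sit, and no measured number exists to compare against.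

Compound 3 `C#CCCCCCc1cc2cn([C@H]3C[C@H](O)[C@@H](CO)O3)c(=O)nc2o1` keeps the shared core and alters only the chain. The difference from compound 2 is but-3-yn-1-yl in place of ethynyl on a saturated chain carbon, three bonds along the chain from an aromatic carbon with but-3-yn-1-yl in place of ethynyl on a saturated chain carbon, three bonds along the chain from an aromatic carbon.

Among the measured compounds shown here, one measured step bears on this change, namely a step that the two limits leave unreadable from compound 1 to compound 2 and it offers no size to carry over. No step beyond the scatter is therefore expected in this assay and no direction can be given. The expectation rests on compound 2 with its > 200000 nM as a limit, and compound 3 will probably also be reported as a limit. The expected change is a number no higher from compound 2 to compound 3 (the limit leaves the size open) and no more. Compound 3 is estimated at 200000 nM with an expected range from 80000 nM to 300000 nM in this reading.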

Compound 3, half-maximal cytotoxic concentration: > 200000 nM
Compound 3 was reported as a limit (the forecaster's own chance of this, stated with the estimate: 80%); the middle value lies on the limit itself.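

In this assay compound 3 gives > 200000 nM, which is a limit and not a number. Among the compounds shown here, no step among compound 1, compound 2 and compound 3 can be read, because all three rest on the same limit: the limit of > 200000 nM in this assay, at which 3 of the 3 values shown sit. The compounds shown leave open whether chain length changes the tolerated concentration at all.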